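The source may report more compounds than this note shows. Statements on the series, on what has been measured and on what is new or still open speak of the compounds shown alone.

In a functional assay on the whole organism for agonist activity, with Mus musculus as the target (on this read-out lower numbers stand for an effect already at smaller amounts and higher numbers for an effect only at larger amounts of compound), three compounds have been measured so far:

compound 1, `COC(=O)N(C)CC#CCN1CCCC1`, gives 5.5 mg/kg
compound 2, `COC(=O)N(C)CC#CCn1ccnc1`, gives 4.5 mg/kg
compound 3, `Cn1ccn(CC#CCN2CCCC2)c1=O`, gives 6.6 mg/kg

A fourth compound, compound 4, `Cn1ccn(CC#CCn2ccnc2)c1=O`, has not yet been measured in this assay.

Compound 1 and compound 2 differ in a single place: 1H-imidazol-1-yl in place of pyrrolidin-1-yl on a saturated chain carbon bound to a triple-bonded carbon. The step this change made is a 1.2-fold lower number from compound 1 to compound 2 (0.09 log units; within the scatter), so the two values are, for practical purposes, indistinguishable in this assay.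

Compound 3 shares with compound 1 the chain ending in pyrrolidin-1-yl, but its other end is built differently; the difference between the two cores is not broken down here. The values of compound 3 and compound 1 lie within the scatter of each other, as do those of compound 3 and compound 2.

Compound 4 relates to compound 3 exactly as compound 2 relates to compound 1: 1H-imidazol-1-yl in place of pyrrolidin-1-yl on a saturated chain carbon bound to a triple-bonded carbon. The group that leaves and the group that enters are the same, and so is the place where the exchange happens, so this is the same change made a second time on a different core. For the measured compounds named here, only one earlier example of it exists, and that one example moved the number very little. On that basis the step from compound 3 to compound 4 is expected to be small as well, a 1.2-fold lower number from compound 3 to compound 4 (0.08 log units; within the scatter), resting on the earlier step of a 1.2-fold lower number from compound 1 to compound 2 (0.09 log units; within the scatter) applied to the value of compound 3, 6.6 mg/kg.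

Compound 4 is therefore estimated to give 5.5 mg/kg in this assay, most likely somewhere between 2.5 mg/kg and 12 mg/kg.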

Compound 4, dose for half-maximal effect: 3.7 mg/kg
Beside the measured number, compound 4's estimate is 1.5-fold (0.17 log units) above it, and the stated range covers the measured number.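

In this assay, the exchange of pyrrolidin-1-yl for 1H-imidazol-1-yl on the second core gives a 1.8-fold lower number from compound 3 to compound 4 (0.25 log units; within the scatter). Set beside the first example, the two results show no real difference between the cores: the same change on two cores in this assay, a 1.2-fold lower number (0.09 log units; within the scatter) from compound 1 to compound 2 and a 1.8-fold lower number (0.25 log units; within the scatter) from compound 3 to compound 4, 1.5-fold (0.16 log units) apart, within the scatter of two such steps. Within this small set, the change therefore carries over from one core to the other with no detectable difference in its size, but neither step stands clear of the usual scatter, so the lower number seen on both cores cannot be taken as a real gain, and two cores are too few to make a rule for any further core.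

The compounds shown leave open whether other groups on a saturated chain carbon bound to a triple-bonded carbon, such as an open-chain amine like dimethylamino or the six-membered piperidin-1-yl, would give a step large enough to stand out from the scatter. They also leave open whether a longer chain between the two ends would change the picture, and whether the exchange would hold on a third core.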